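The compounds below may be only part of what the source reports. "The series", "measured", "known", "first", "only" and "open" are said of these compounds alone.

Working notes on the series. In an ADME assay for permeability, using PAMPA, at pH 7.4 (a higher number here means that the compound crosses the layer faster, a lower number that the compound crosses the layer more slowly), compound 1 `CC(C)COc1ncc(-c2cn(C)c3cc(C(=O)NS(C)(=O)=O)ccc23)cc1Cl` gives 216 nm/s and compound 2 `Cn1cc(-c2ccc(C(F)(F)F)cc2)c2cc(F)c(C(=O)NS(=O)(=O)C3CC3)cc21` gives 323 nm/s as its apparent permeability. Among the compounds with values here, these two values lie within the usual scatter of each other, so compound 2 stands level with the only other measured compound.

Within the data shown here, compound 3 `Cn1cc(-c2ccc(C(F)(F)F)cc2)c2ccc(C(=O)NS(=O)(=O)C3CC3)cc21` differs from compound 2 by hydrogen in place of fluoro on an aromatic carbon as its single change. This is hydrogen in place of fluoro on an aromatic carbon, ortho to a (cyclopropylsulfonyl)carbamoyl group.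

Among the measured compounds shown here, no measured pair shows this change, so the data offer no direct size for it. In this assay no step beyond the scatter is expected, and neither direction is favoured. The estimated 1.1-fold lower number from compound 2 to compound 3 (0.05 log units; within the scatter) is expected to stay within the scatter. For compound 3 the expected value is 290 nm/s as a central estimate. The estimated range for compound 3 runs from 140 nm/s to 560 nm/s on this read-out.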

Compound 3, apparent permeability: 135 nm/s
Compound 3: middle estimate off by 2.1-fold (0.33 log units), on the high side; the measured number lies below the stated range.
By their numbers in this assay, from the lowest: compounds 3, 1 and 2 (each within the scatter of the next, the first and the last beyond it).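

In this assay, within the data shown here, hydrogen in place of fluoro on an aromatic carbon, ortho to a (cyclopropylsulfonyl)carbamoyl group, gives a 2.4-fold lower number from compound 2 to compound 3 (0.38 log units; beyond the scatter), the first one-place step and a modest one beyond the scatter. This position therefore matters to this read-out, even though the change removes only 1 heavy atom, something the earlier comparison of compound 1 and compound 2 could not show, as those compounds differ in more than one place. Nothing at hand bears on the reason for this step.

This single pair leaves open whether a step of this size and direction would hold on the core of compound 1. It also leaves open where a nitrile or a methoxy group at this position would fall relative to fluoro and hydrogen.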